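Swapping the ether acid chain for an alkenyl acid

The source may hold more compounds than are shown below. What is called first, only, known or untested is meant among the compounds shown, and "the series" means these compounds.

Three compounds with measured inhibition are compared here. Compound 1 `O=C(O)COCCCC[C@H]1[C@H](F)CC[C@@H]1NS(=O)(=O)c1ccc(F)cc1` gives 1800 nM in a functional assay on a cell-free system (plasma) for inhibition of thromboxane A2 receptor (Homo sapiens), read by turbidimetry; a higher number here means a weaker inhibitor, a lower number a stronger inhibitor. Compound 3 `Cc1ccc(S(=O)(=O)N[C@H]2CCC=C2CCCCOCC(=O)O)cc1` gives 1900 nM in this assay, a number within the scatter of compound 1, so the two cannot be ordered. Compound 2 `O=C(O)CC/C=C\C[C@@H]1[C@@H](CNS(=O)(=O)c2ccc(F)cc2)CC[C@@H]1F` gives 650 nM, which lies beyond the scatter below compound 1, so compound 1 holds the second highest of the three numbers. Compound 4 `O=C(O)CC/C=C\C[C@H]1[C@H](F)CC[C@@H]1NS(=O)(=O)c1ccc(F)cc1` has not yet been measured. It differs from compound 1 in one place: 4-carboxybut-1-en-1-yl in place of 3-(carboxymethoxy)propyl on a saturated chain carbon bound to a saturated ring carbon. Among the measured compounds shown here, the chain that enters is the one carried by compound 2, whose value of 650 nM is the lowest of the three; compound 2, however, also differs from compound 4 in how the sulfonamide is joined to the core, so no step between them is given. On this basis, the step from compound 1 to compound 4 is expected to be a modest move toward a lower number, a 2.0-fold lower number from compound 1 to compound 4 (0.30 log units; within the scatter), though a result within the scatter would not surprise. Compound 4 is therefore estimated at 900 nM, with a range from 300 nM to 2700 nM.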

Compound 4, half-maximal inhibitory concentration: 750 nM
Compound 4: the middle estimate sits 1.2-fold (0.08 log units) above what was measured; the range from low to high includes it.
By their numbers in this assay, from the lowest: compounds 2 and 4 (each within the scatter of the next); then compounds 1 and 3 (each within the scatter of the next).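

The change of 3-(carboxymethoxy)propyl to 4-carboxybut-1-en-1-yl on a saturated chain carbon bound to a saturated ring carbon gives a 2.4-fold lower number from compound 1 to compound 4 (0.38 log units; beyond the scatter) in this assay and is the only single-place comparison among these compounds. Among the compounds shown here, it therefore gives the first direct evidence that the make-up of the acid chain at this position alters the number, beyond the scatter though only modestly. Nothing measured here accounts for the shift.

The change removes the ether oxygen and adds a double bond together, so the compounds shown do not separate these two features. On these data alone, a fully saturated all-carbon acid chain would address that question, while a longer chain or a tetrazole in place of the carboxylic acid remains unexplored at this position.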